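A few compounds are considered here, and "the series" means these few. Any claim that something is new, unique, unknown or untested is made for them only; others in the source may bear on it.

Of the compounds shown here, three built on one shared core have been measured in a functional assay on U-937 cells (Homo sapiens) for cytotoxicity, read by MTT assay, with a stated time of 48 h; on this read-out higher numbers stand for weaker inhibition and lower numbers for stronger inhibition. Compound 1 `Cc1ccc2nc(Nc3nc4ccccc4s3)sc2c1` gives 48400 nM. Compound 2 `Clc1ccc2nc(Nc3nc4ccccc4s3)sc2c1` gives in this assay only a limit, > 50000 nM, and no number. Compound 3 `CCOc1ccc2nc(Nc3nc4ccc(F)cc4s3)sc2c1` gives 26600 nM, the lower of the two numbers obtained, though its gap to compound 1 lies within the usual scatter, so the two cannot be told apart. Compound 4 `Cc1ccc2nc(Nc3nc4ccc(F)cc4s3)sc2c1` has not yet been measured; it differs from compound 3 by methyl in place of ethoxy on an aromatic carbon. Among the measured compounds shown here, the only measured step, an at least 1.0-fold higher number from compound 1 to compound 2 (0.01 log units; that floor lies within the scatter), exchanges methyl for chloro and ends at the limit of > 50000 nM in this assay, at which 1 of the 3 values shown sits, so it says little about replacing an ethoxy, and no measured pair shows that exchange by itself. Compound 1 and compound 3 differ in two places at once, and their values sit within the scatter of one another. For compound 4 the step of a 1.5-fold higher number from compound 3 to compound 4 (0.18 log units; within the scatter) is therefore expected to remain within the scatter. Compound 4 is accordingly estimated at 40000 nM, between 20000 nM and 80000 nM, with a fair chance that this assay reports only a limit.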

Compound 4, half-maximal inhibitory concentration: > 50000 nM
Compound 4 gave a limit, no number (the forecaster's own chance of this, stated with the estimate: 40%); middle value at least 1.2-fold (0.09 log units) away from the limit.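

In this assay, the exchange of ethoxy for methyl at this position now has a measured pair of its own, and it gives an at least 1.8-fold higher number from compound 3 to compound 4 (0.27 log units; that floor lies within the scatter). As far as these compounds go, the full size of this step stays unknown, since compound 4 reads only as a limit, and the real gap could be close to this floor or much larger: the limit of > 50000 nM in this assay, at which 2 of the 4 values shown sit. Fluoro in place of hydrogen can now also be read by itself, as an at least 1.0-fold higher number from compound 1 to compound 4 (0.01 log units; that floor lies within the scatter), so this single exchange shows no move towards stronger inhibition.

The compounds shown leave open how ethoxy behaves on the core of compound 1 without the fluoro. They also leave open whether an amine, a carboxylic acid or a longer chain such as butoxy at this position would give a clearly lower number.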